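Nitro in place of cyano on an aromatic carbon

The compounds below may be only part of what the source reports. "The series", "measured", "known", "first", "only" and "open" are said of these compounds alone.

Measured in a functional assay on the whole organism for activation, with Mus musculus as the target, with a stated time of 60 min; a higher number here means that more compound is needed for the effect, a lower number that less compound is needed:
- compound 1 `N#Cc1ccc(-c2ccc(/C=N/N3C(=O)NC(=O)C3O)o2)cc1` gives 156 mg/kg
- compound 2 `O=C1CN(/N=C/c2ccc(-c3cccc(C(F)(F)F)c3)o2)C(=O)N1` gives 143 mg/kg
- compound 3 `O=C1NC(=O)N(/N=C/c2ccc(-c3cccc(C(F)(F)F)c3)o2)C1O` gives 244 mg/kg

Compound 1 (156 mg/kg) lies within the scatter of both compound 2 and compound 3. Compound 4 `O=C1NC(=O)N(/N=C/c2ccc(-c3ccc([N+](=O)[O-])cc3)o2)C1O` differs from compound 1 by nitro in place of cyano on an aromatic carbon, para to a large group (nitro in place of cyano on an aromatic carbon). Going by the values given here, no measured step covers this exchange. The only one available, hydroxy in place of hydrogen on a saturated ring carbon (a 1.7-fold higher number from compound 2 to compound 3 (0.23 log units; within the scatter)), is a different change and stays within the scatter. No step beyond the scatter is therefore expected in this assay. The estimated step is a 1.1-fold higher number from compound 1 to compound 4 (0.04 log units; within the scatter) and so remains within the scatter. For compound 4 the expected value is 170 mg/kg with an estimated range from 90 mg/kg to 320 mg/kg as the likely spread.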

Compound 4, dose for half-maximal effect: > 1000 mg/kg
Compound 4: a limit, no number (the forecaster's own chance of this, stated with the estimate: 3%); at least 5.8-fold (0.76 log units) between middle value and limit.
By their numbers in this assay, from the lowest: compounds 2, 1 and 3 (each within the scatter of the next). At a limit, above all of these: compound 4.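

Nitro in place of cyano on this aromatic carbon, para to a large group, gives an at least 6.4-fold higher number from compound 1 to compound 4 (0.80 log units; beyond the scatter) in this assay. Among compound 1, compound 2 and compound 3, no listed step or printed comparison goes beyond the scatter, so this is the only exchange shown to change the result clearly. Compound 4 gives > 1000 mg/kg, which is a limit of the assay and not a number, so the full size of the step stays unknown: the limit of > 1000 mg/kg in this assay, at which 1 of the 4 values shown sits.

The compounds shown leave open how an amine or a carboxylic acid at this position would read in this assay. As far as these compounds go, whether the step is specific to nitro also remains open.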